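The compounds below may be only part of what the source reports. "The series", "measured", "known", "first", "only" and "open" are said of these compounds alone.

Compound 1 `CCN(CC)CN1C(=O)/C(=N\c2nc3ccc(C)cc3s2)c2c(Br)cccc21` and compound 2 `O=C1C(=O)N(CN2CCCCC2)c2cccc(Br)c21` are built on related cores, but the difference between the two cores is not broken down here. In a functional assay on MDA-MB-468 cells (Homo sapiens) for cytotoxicity, read by sulforhodamine B assay, with a stated time of 48 h (on this read-out lower numbers stand for stronger inhibition of growth and higher numbers for weaker inhibition of growth), compound 1 gives 43100 nM and compound 2 gives 35300 nM; these two numbers lie within the scatter of each other. Compound 3 `O=C1C(=O)N(CN2CCCCC2)c2cccc(Cl)c21` differs from compound 2 by chloro in place of bromo on an aromatic carbon, and in this assay compound 3 gives 82800 nM, which is a 2.3-fold higher number from compound 2 to compound 3 (0.37 log units; beyond the scatter). Compound 4 `CCN(CC)CN1C(=O)/C(=N\c2nc3ccc(C)cc3s2)c2c(Cl)cccc21` differs from compound 1 by chloro in place of bromo on an aromatic carbon, the same kind of change at the same kind of place. Among the compounds with values here, a step of similar size is expected here, a 2.1-fold higher number from compound 1 to compound 4 (0.32 log units; beyond the scatter), because the one earlier instance of this change gave a 2.3-fold higher number from compound 2 to compound 3 (0.37 log units; beyond the scatter). For compound 4 the expected value in this assay is 90000 nM, with an estimated range from 45000 nM to 180000 nM.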

Compound 4, concentration for 50% growth inhibition: 27300 nM
Beside the measured number, compound 4's estimate is 3.3-fold (0.52 log units) above it; the whole stated range lies above it.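

In this assay putting chloro in place of bromo gives a 1.6-fold lower number from compound 1 to compound 4 (0.20 log units; within the scatter) and so makes no clear difference on the core of compound 1. The same change therefore does not carry over as a step of similar size from one core to the other: the same change on two cores in this assay, a 2.3-fold higher number (0.37 log units; beyond the scatter) from compound 2 to compound 3 and a 1.6-fold lower number (0.20 log units; within the scatter) from compound 1 to compound 4, 3.7-fold (0.57 log units) apart, beyond the scatter of two such steps. This shows that a step seen on one core cannot simply be transferred to the other here, but with one pair per core it does not show why the two differ.

Still open, on these data alone, is how other groups on the same aromatic carbon, such as fluoro, methyl or methoxy, would behave on each core. Also open, as far as these compounds go, is whether either core would respond to them in the same way as the other.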